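Amide Substituent and Maximal Response at the Dopamine D4 Receptor

The source may report more compounds than this note shows. Statements on the series, on what has been measured and on what is new or still open speak of the compounds shown alone.

Measured compounds:
compound 1 `O=C(CN1CCC(c2cccc[n+]2[O-])CC1)Nc1cccc(F)c1`, 70%
compound 2 `Cc1cc(NC(=O)CN2CCC(c3cccc[n+]3[O-])CC2)ccc1F`, 75%
compound 3 `O=C(CN1CCC(c2cccc[n+]2[O-])CC1)NC1CCCCC1`, 58%

In a functional assay on HEK293 cells for agonist activity at D(4) dopamine receptor (Homo sapiens), read by FLIPR (a higher number here means a larger maximal response, a lower number a smaller maximal response), compound 3 stands lowest of the three; compound 1 lies nearer to it and compound 2 furthest from it, both beyond the scatter. The step of a number 12 percentage points lower from compound 1 to compound 3 (beyond the scatter) and the step of a number 17 percentage points lower from compound 2 to compound 3 (beyond the scatter) both show that putting cyclohexyl on the amide-type nitrogen in place of an aromatic ring lowered the maximal response by a modest amount, while the step of a number 5 percentage points higher from compound 1 to compound 2 (within the scatter) between the two aromatic amides stayed within the scatter.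

Compound 4 `O=C(CN1CCC(c2cccc[n+]2[O-])CC1)Nc1ccc(F)cc1` is not yet measured. It differs from compound 3 by 4-fluorophenyl in place of cyclohexyl on an amide-type nitrogen. This change runs in the opposite direction to the two steps that lowered the response, so a modest rise in this assay is expected, of roughly the size seen in those steps. Compound 4 is therefore expected to give about 70% in this assay, with a range from 58% to 82%, a step of a number 12 percentage points higher from compound 3 to compound 4 (beyond the scatter) that is estimated, not measured.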

Compound 4, largest response reached (reported as efficacy), in percent of the reference or control that the assay uses: 71%
Compound 4: middle estimate off by 1 percentage points, on the low side, and the stated range covers the measured number.
By their numbers in this assay, from the lowest: compound 3; then compounds 1, 4 and 2 (each within the scatter of the next).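

In this assay, the step of a number 13 percentage points higher from compound 3 to compound 4 (beyond the scatter) compares cyclohexyl directly with 4-fluorophenyl on the amide-type nitrogen. All three aromatic amides now stand clear of the cyclohexyl amide, and no compound shown goes against this. The step of a number 1 percentage points higher from compound 1 to compound 4 (within the scatter) shows that 3-fluorophenyl and 4-fluorophenyl cannot be told apart here, and the step of a number 4 percentage points lower from compound 2 to compound 4 (within the scatter) shows the same for hydrogen in place of methyl on an aromatic carbon, while no measurement bears on why the cyclohexyl amide differs from the aromatic amides.

The compounds shown leave open whether the aromatic ring itself is enough, as unsubstituted phenyl would test, or whether an amine or a carboxylic acid on that ring would keep the response. They also leave open how a benzyl group, with its longer chain to the ring, would compare on the same nitrogen.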